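The source may hold more compounds than are shown below. What is called first, only, known or untested is meant among the compounds shown, and "the series" means these compounds.

Four large ring-shaped peptide-like compounds share a common core, and three of them have been tested. Compound 1 `N=C(N)NCCC[C@@H]1NC(=O)c2ccc(cc2)-c2cccc3c(c[nH]c23)C[C@H](C(N)=O)NC(=O)[C@H](Cc2ccccc2)NC(=O)[C@H](CC(=O)O)NC(=O)CNC1=O` gives 9290 nM in an assay on a protein complex for binding affinity to integrin alpha-5/beta-1 (Homo sapiens), read by ELISA, with a stated time of 1 h; a lower number here means a stronger inhibitor, a higher number a weaker inhibitor. Compound 3 `CN1C(=O)[C@@H](Cc2ccccc2)NC(=O)[C@H](CC(=O)O)NC(=O)CNC(=O)[C@H](CCCNC(=N)N)NC(=O)c2ccc(cc2)-c2cccc3c(c[nH]c23)C[C@H]1C(N)=O` gives 2160 nM in this assay, and the two numbers show compound 3 as the stronger binder of that pair. Compound 2 `N=C(N)NCCC[C@@H]1NC(=O)c2ccc(cc2)-c2ccc3c(c[nH]c3c2)C[C@H](C(N)=O)NC(=O)[C@H](Cc2ccccc2)NC(=O)[C@H](CC(=O)O)NC(=O)CNC1=O` is a close relative of compound 1. In this assay compound 2 reached only the limit, > 10000 nM. This limit sets compound 2 at the weak end of everything seen so far (the limit of > 10000 nM in this assay, at which 1 of the 3 values shown sits), with no exact number known for it.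

Compound 4 `CN1C(=O)[C@H](Cc2ccccc2)NC(=O)[C@H](CC(=O)O)NC(=O)CNC(=O)[C@H](CCCNC(=N)N)NC(=O)c2ccc(cc2)-c2ccc3c(c[nH]c3c2)C[C@@H]1C(N)=O` has not yet been measured. It differs from compound 2 by methyl in place of hydrogen on an amide-type nitrogen in a ring. Because compound 3 with its methyl on that nitrogen sits at 2160 nM while compound 1 sits at 9290 nM, a move toward stronger binding is expected, larger than the scatter. The step is expected to be an at least 1.6-fold lower number from compound 2 to compound 4 (0.22 log units; that floor lies within the scatter). Compound 4 is thus estimated at 6000 nM, with a likely range from 2500 nM to 15000 nM.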

Compound 4, half-maximal inhibitory concentration: 2720 nM
Compound 4: middle estimate off by 2.2-fold (0.34 log units), on the high side; measured number inside the range.
By their numbers in this assay, from the lowest: compounds 3 and 4 (each within the scatter of the next); then compound 1. At a limit, above all of these: compound 2.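

Methyl in place of hydrogen on this amide-type nitrogen gives an at least 3.6-fold lower number from compound 2 to compound 4 (0.56 log units; beyond the scatter) in this assay, a change beyond the usual scatter. As far as these compounds go, compound 2 has only a limit of the assay, so this step is a floor and its true size stays unknown: the limit of > 10000 nM in this assay, at which 1 of the 4 values shown sits. The lower number with methyl, so far seen only from compound 1 at 9290 nM to compound 3 at 2160 nM, now appears in a second pair, and the two methyl compounds, compound 3 at 2160 nM and compound 4 at 2720 nM, lie within the scatter of each other.

The compounds shown leave open whether only methyl does this, or whether an ethyl group or a longer chain on the same nitrogen would serve as well. They also do not tell why the number falls when the amide hydrogen is replaced.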